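Compound 3 to compound 4: a larger group on sulfur

The source may report more compounds than this note shows. Statements on the series, on what has been measured and on what is new or still open speak of the compounds shown alone.

Measured in an ADME assay (liver) for metabolic stability, with Liver microsome (Homo sapiens) as the target, read by LC-MS, using microsomes and NADPH, with a stated time of 5 min, at 37 degrees C; on this read-out lower numbers stand for slow clearance and higher numbers for fast clearance:
compound 1 `CCn1c([C@@H](C)NS(=O)(=O)c2ccc(C#N)cc2)nc2ccc(C(F)(F)F)cc21`: 34 mL.min-1.g-1
compound 2 `CCn1c([C@@H](C)NS(=O)(=O)c2cn(C)nc2C)nc2ccc(C(F)(F)F)cc21`: 28 mL.min-1.g-1
compound 3 `CCn1cc(S(=O)(=O)N[C@H](C)c2nc3ccc(C(F)(F)F)cc3n2CC)cn1`: 95 mL.min-1.g-1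

Of these three, compound 3 stands highest, at 95 mL.min-1.g-1, and both of the others lie beyond the scatter from it. The values of compound 1 and compound 2 differ only within the scatter, as shown by a 1.2-fold lower number from compound 1 to compound 2 (0.08 log units; within the scatter).

The next compound is compound 4 `CCCn1ncc(S(=O)(=O)N[C@H](C)c2nc3ccc(C(F)(F)F)cc3n2CC)c1C`, and the change is 5-methyl-1-propyl-1H-pyrazol-4-yl in place of 1-ethyl-1H-pyrazol-4-yl on a sulfonyl sulfur. The place is again on a sulfonyl sulfur, with the core untouched.

For the measured compounds named here, two measured steps bear on it, both made at that same place: a 2.8-fold higher number from compound 1 to compound 3 (0.45 log units; beyond the scatter) and a 3.4-fold higher number from compound 2 to compound 3 (0.53 log units; beyond the scatter). The second is the closer guide, since it also exchanges one substituted ring for another. Going by the values given here, the entering group carries a methyl, as the group in compound 2 does, but also a propyl chain, and no measured step isolates either feature. A modest fall from compound 3 is therefore possible, but the evidence is thin, and no step beyond the scatter is expected in this assay. The expected step is small and leans downward: a 1.4-fold lower number from compound 3 to compound 4 (0.13 log units; within the scatter).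

For compound 4 the estimated value is 70 mL.min-1.g-1, with an expected range from 32 mL.min-1.g-1 to 160 mL.min-1.g-1.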

Compound 4, intrinsic clearance in microsomes: > 100 mL.min-1.g-1
Compound 4: a limit, no number; the forecaster's own chance of this, stated with the estimate: 2%; middle value at least 1.4-fold (0.15 log units) away from the limit.
By their numbers in this assay, from the lowest: compounds 2 and 1 (each within the scatter of the next); then compound 3. At a limit, above all of these: compound 4.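

In this assay compound 4 gives > 100 mL.min-1.g-1, which is a limit of the assay and not a number: the limit of > 100 mL.min-1.g-1 in this assay, at which 1 of the 4 values shown sits.
The floors of an at least 3.5-fold higher number from compound 2 to compound 4 (0.55 log units; beyond the scatter) and an at least 2.9-fold higher number from compound 1 to compound 4 (0.46 log units; beyond the scatter) both lie beyond the scatter, so the 5-methyl-1-propyl-1H-pyrazol-4-yl group on the sulfonyl sulfur does not share the low numbers of the 1,3-dimethyl-1H-pyrazol-4-yl and 4-cyanophenyl groups, even though it carries a methyl as the dimethyl group does. As far as these compounds go, the remaining step, an at least 1.0-fold higher number from compound 3 to compound 4 (0.02 log units; that floor lies within the scatter), has a floor within the scatter, so its true size stays unknown and the change from 1-ethyl-1H-pyrazol-4-yl can be read only as far as that floor.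

The compounds shown do not separate the contribution of the propyl chain from that of the methyl in the entering group. They also leave open how a pyrazole bearing a methoxyethyl chain or a carboxylic acid in place of the propyl chain would read in this assay.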